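This account rests on a few compounds, and the source may have more. Where it says the series, first, only, none or still open, it means among the compounds named here.

In a functional assay on HL-60 cells (Homo sapiens) for inhibition, read by CCK-8 assay, with a stated time of 48 h (a lower number here means a stronger inhibitor, a higher number a weaker inhibitor), compound 1, `O=C(NCCNS(=O)(=O)c1sccc1-c1ccccc1Oc1ccc(O)c(O)c1)Nc1cc(Cl)cc(Cl)c1`, gives 6900 nM. Compound 3, `CC(C)c1ccc(Oc2ccc(O)c(O)c2)c(-c2ccsc2S(=O)(=O)NCCNC(=O)Nc2cc(Cl)cc(Cl)c2)c1`, carries one alteration relative to compound 1, (isopropyl in place of hydrogen on an aromatic carbon), and in this assay compound 3 gives 6500 nM, a step of a 1.1-fold lower number from compound 1 to compound 3 (0.03 log units; within the scatter). Compound 2, `COc1ccc(Oc2ccccc2-c2ccsc2S(=O)(=O)NCCNC(=S)Nc2cc(C(F)(F)F)cc(C(F)(F)F)c2)cc1OC`, rests on a different core; the difference between the two cores is not broken down here. In this assay compound 2 gives 2800 nM, the lowest of the three numbers and beyond the scatter from both others. Compound 4, `COc1ccc(Oc2ccc(C(C)C)cc2-c2ccsc2S(=O)(=O)NCCNC(=S)Nc2cc(C(F)(F)F)cc(C(F)(F)F)c2)cc1OC`, differs from compound 2 by isopropyl in place of hydrogen on an aromatic carbon, the same kind of change as that from compound 1 to compound 3, though here the place is para to a 3,4-dimethoxyphenoxy group rather than a 3,4-dihydroxyphenoxy group. Because that earlier step a 1.1-fold lower number from compound 1 to compound 3 (0.03 log units; within the scatter) stayed within the scatter, the step from compound 2 to compound 4 in this assay is expected to be about a 1.0-fold lower number from compound 2 to compound 4 (0.02 log units; within the scatter). Compound 4 is accordingly estimated at 2700 nM, between 1200 nM and 6000 nM.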

Compound 4, half-maximal inhibitory concentration: 6900 nM
Compound 4: the middle estimate sits 2.6-fold (0.41 log units) below what was measured; measured number outside the range, above it.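

In this assay, placing isopropyl on the aromatic carbon of compound 2 gives a 2.5-fold higher number from compound 2 to compound 4 (0.39 log units; beyond the scatter), a step that is real on this core. Set beside the same change on the core of compound 1, however, this step cannot be told apart from the earlier one: the same change on two cores in this assay, a 1.1-fold lower number (0.03 log units; within the scatter) from compound 1 to compound 3 and a 2.5-fold higher number (0.39 log units; beyond the scatter) from compound 2 to compound 4, 2.6-fold (0.42 log units) apart, within the scatter of two such steps. These two pairs therefore do not show that the change carries over unaltered from one core to the other, nor do they show that its outcome depends on the core.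

The compounds shown leave open how a methyl group, a tert-butyl group or a carboxylic acid would behave at the same place. They also leave open which of the differences between the two cores, if any, bears on the step.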